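Urea substituent variation on a thienopyrimidine antiproliferative series

The compounds below may be only part of what the source reports. "The series", "measured", "known", "first", "only" and "open" are said of these compounds alone.

Measured compounds:
compound 1 `CCCNC(=O)N1CCN(c2ncnc3sc(-c4ccc(N5CCN(C)CC5)cc4)cc23)CC1` gives 8330 nM in a functional assay on MDA-MB-231 cells (Homo sapiens) for antiproliferative activity, read by MTT assay, with a stated time of 48 h; a higher number here means a weaker inhibitor, a lower number a stronger inhibitor
compound 2 `CN1CCN(c2ccc(-c3cc4c(N5CCN(C(=O)Nc6ccccc6)CC5)ncnc4s3)cc2)CC1` gives 7590 nM in this assay

Compound 2 holds the lower of the two numbers in this assay, but its neighbour compound 1 sits a 1.1-fold lower number from compound 1 to compound 2 (0.04 log units; within the scatter), so the two are not separated beyond the scatter.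

Compound 3 `CN1CCN(c2ccc(-c3cc4c(N5CCN(C(=O)Nc6ccc(F)cc6F)CC5)ncnc4s3)cc2)CC1` has not yet been measured in this assay. Its change from compound 2 is 2,4-difluorophenyl in place of phenyl on an amide-type nitrogen; read one bond further out, phenylcarbamoyl becomes (2,4-difluorophenyl)carbamoyl.

Within the data shown here, the only measured step, propyl to phenyl at the same amide-type nitrogen, is a 1.1-fold lower number from compound 1 to compound 2 (0.04 log units; within the scatter), within the scatter. Among the measured compounds shown here, no measured pair shows what adding fluorine to that phenyl does, so there is no basis for expecting movement in either direction beyond the scatter in this assay.

Compound 3 is therefore expected to give about 7000 nM, with a range of 3000 nM to 16000 nM.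

The expected change is a 1.1-fold lower number from compound 2 to compound 3 (0.04 log units; within the scatter).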

Compound 3, half-maximal inhibitory concentration: 11400 nM
For compound 3 the middle estimate is 1.6-fold (0.21 log units) below the measured one; low and high end bracket the measured number.
By their numbers in this assay, from the lowest: compounds 2, 1 and 3 (each within the scatter of the next).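

In this assay the change to 2,4-difluorophenyl on the amide-type nitrogen gives a 1.5-fold higher number from compound 2 to compound 3 (0.18 log units; within the scatter) and the same group in place of propyl gives a 1.4-fold higher number from compound 1 to compound 3 (0.14 log units; within the scatter) so adding fluorine to the phenyl does not separate the compounds. Propyl, phenyl and 2,4-difluorophenyl at this position therefore all lie within the scatter of one another, and among these three compounds the position shows no resolved response to the substituent. No available data bear on why these steps are so small.

Going by these compounds, it remains open whether an amine or a carboxylic acid on the phenyl, or a longer chain in place of propyl, would move the number beyond the scatter. Also open, on these data alone, is whether a single fluorine on the phenyl would read differently from 2,4-difluorophenyl.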